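The source may report more compounds than this note shows. Statements on the series, on what has been measured and on what is new or still open speak of the compounds shown alone.

Of the compounds shown here, two on the shared core have been read so far in a functional assay on MCF7 cells (Homo sapiens) for inhibition, read by resazurin assay, with a stated time of 24 h (a higher number here means a weaker inhibitor, a lower number a stronger inhibitor), and only one of them gives a number. Compound 1 (`O=C1Nc2c(C(F)(F)F)cccc2C1(c1ccc(OC(F)(F)F)cc1)c1ccc(OC(F)(F)F)cc1`) gives > 1000 nM as a limit of the assay and not a number. Among the measured compounds shown here, compound 2 (`O=C1Nc2c(C(F)(F)F)cccc2[C@]1(c1ccc(OC(F)(F)F)cc1)c1ccc(O)c(O)c1`) gives 24 nM as the only number on hand. Compound 3 (`O=C1Nc2c(C(F)(F)F)cccc2C1(c1ccc(OC(F)(F)F)cc1)c1ccc(O)c(O)c1`) differs from compound 2 by the two compounds have the same atoms and bonds; at least one stereo element is drawn with a configuration in one of them and without one in the other: 1 of 1 stereo elements differ; a stereocentre at a saturated ring carbon is drawn S in compound 2 and without a configuration in compound 3 and has the same atoms and bonds: a stereocentre at a saturated ring carbon is drawn S in compound 2 and without a configuration in compound 3. Compound 3 is therefore expected to stay close to compound 2 with its 24 nM as the reference. The expected step of a 1.7-fold higher number from compound 2 to compound 3 (0.22 log units; within the scatter) is a small weakening that may stay within the usual scatter. The estimate for compound 3 is 40 nM in this assay with an expected range from 18 nM to 110 nM across repeated measurements.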

Compound 3, half-maximal inhibitory concentration: 49 nM
For compound 3 the middle estimate is 1.2-fold (0.09 log units) below the measured one; low and high end bracket the measured number.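

In this assay, the change to 3,4-dihydroxyphenyl in place of 4-(trifluoromethoxy)phenyl on a saturated ring carbon can now be read in a single place, as an at least 20-fold lower number from compound 1 to compound 3 (1.30 log units; beyond the scatter), a large step known from one side only: the limit of > 1000 nM in this assay, at which 1 of the 3 values shown sits.

With the atoms and bonds unchanged, the stereocentre at the saturated ring carbon still comes with a 2.0-fold higher number from compound 2 to compound 3 (0.31 log units; beyond the scatter), a modest step that shows the way this centre is drawn goes along with a difference in the number. The step can be tied to one thing only: the fact that one of compounds 2 and 3 is drawn with a defined configuration and the other without, at the place where they differ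

The compounds shown leave open how the R configuration at this carbon reads on its own. They also leave open whether a single hydroxyl, or two methoxy groups in place of the two hydroxyls, would keep the number near that of compound 2.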